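Chromene series: chloro for ethoxy at the fused ring

The source may hold more compounds than are shown below. What is called first, only, known or untested is meant among the compounds shown, and "the series" means these compounds.

Measured so far:
- compound 1, `N#CC1=C(N)Oc2c(ccc(N)c2N)C1c1cccc(C#N)c1`, a functional assay on T47D cells (Homo sapiens) for activation; on this read-out higher numbers stand for an effect only at larger amounts of compound and lower numbers for an effect already at smaller amounts: 390000000 nM
- compound 2, `CCOc1ccc2c(c1)OC(N)=C(C#N)C2c1cc(Br)c(OC)c(OC)c1`, this assay: 64000000 nM

Compound 2 holds the lowest of the two numbers seen so far; compound 1 gives the higher number, and the gap between them lies beyond the usual scatter of repeated measurements. Among the measured compounds shown here, no two measured compounds differ in one place only, so no single structural step has yet been measured against this read-out.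

Compound 3, `COc1cc(C2C(C#N)=C(N)Oc3cc(Cl)ccc32)cc(Br)c1OC`, is the next compound to be measured. It differs from compound 2 as follows:

chloro in place of ethoxy on an aromatic carbon

For the measured compounds named here, compound 2 remains the only comparison available, and nothing measured so far tells how a change at this position moves the read-out. The expectation is therefore a step of no more than scatter size, a 1.3-fold higher number from compound 2 to compound 3 (0.10 log units; within the scatter), with the direction left open. On that basis compound 3 is expected to give about 80000000 nM in this assay, with a plausible range from 20000000 nM to 320000000 nM.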

Compound 3, half-maximal effective concentration: 160000000 nM
Beside the measured number, compound 3's estimate is 2.0-fold (0.30 log units) below it, and the stated range covers the measured number.
By their numbers in this assay, from the lowest: compound 2; then compound 3; then compound 1.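

The ethoxy position on the fused ring system now has its first single-place step in this assay: chloro in place of ethoxy gives a 2.5-fold higher number from compound 2 to compound 3 (0.40 log units; beyond the scatter) and so shifts the read-out by a modest amount beyond the scatter. The position is therefore not silent in this assay, and of this pair the ethoxy compound is the one active at smaller amounts. The swap replaces ethoxy, with 3 heavy atoms and 1 hydrogen-bond acceptor, by chloro, with 1 heavy atom and no hydrogen-bond acceptor, but no measurement bears on what lies behind the shift.

A single pair cannot separate the contributions of chain length, the ether oxygen and the chlorine, so the trend at this position remains undefined; a methoxy group, a longer propoxy chain, an amine or plain hydrogen on the same carbon would help to define it. As far as these compounds go, it also remains open whether the same swap gives a similar step when the bromo and dimethoxy substituents on the other aromatic ring are changed.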